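Amino in place of chloro on a shared core

The source may hold more compounds than are shown below. What is called first, only, known or untested is meant among the compounds shown, and "the series" means these compounds.

Compound 1 `ClCc1ccccc1Cn1cnc2c(Cl)nc(Cl)nc21` and compound 2 `ClCc1cccc(Cn2cnc3c(Cl)nc(Cl)nc32)c1` are built from the same atoms joined differently; the difference between the two cores is not broken down here. In a functional assay on NCI-H23 cells (Homo sapiens) for cytotoxicity, read by sulforhodamine B assay, with a stated time of 48 h (a lower number here means that less compound is tolerated, a higher number that more compound is tolerated), compound 1 gives 6310 nM, and in this assay compound 2 gives 22400 nM. Compound 3 `Nc1nc(Cl)c2ncn(Cc3ccccc3CCl)c2n1` arises from compound 1 by amino in place of chloro on an aromatic carbon, and in this assay compound 3 gives 78900 nM, a step of a 13-fold higher number from compound 1 to compound 3 (1.10 log units; beyond the scatter). Compound 4 `Nc1nc(Cl)c2ncn(Cc3cccc(CCl)c3)c2n1`, not yet measured, arises from compound 2 by the same change, (amino in place of chloro on an aromatic carbon), at a place described in the same words. Within the data shown here, for compound 4 a step of about the same size is expected, a 13-fold higher number from compound 2 to compound 4 (1.10 log units; beyond the scatter), because the one earlier instance of this change gave a 13-fold higher number from compound 1 to compound 3 (1.10 log units; beyond the scatter). Compound 4 is therefore estimated at 280000 nM in this assay, within a range expected from 100000 nM to 800000 nM.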

Compound 4, concentration lethal to 50% of the cells: 26900 nM
Compound 4: the middle estimate sits 10-fold (1.02 log units) above what was measured; measured number below the stated range.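

In this assay, amino in place of chloro on an aromatic carbon gives a 1.2-fold higher number from compound 2 to compound 4 (0.08 log units; within the scatter), a step that does not stand out from the scatter of repeated measurements. The size of the step therefore did not carry over from one core to the other: the same change on two cores in this assay, a 13-fold higher number (1.10 log units; beyond the scatter) from compound 1 to compound 3 and a 1.2-fold higher number (0.08 log units; within the scatter) from compound 2 to compound 4, 10-fold (1.02 log units) apart, beyond the scatter of two such steps. With a single pair on each core, this shows that the step cannot be transferred between these two cores, but not what in the cores sets it, nor what size it would take on any further core.

The compounds shown leave open how a methoxy or a dimethylamino group in place of the same chloro would read on each core. Going by these compounds, whether either would differ between the cores as amino does also remains open.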